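The source may hold more compounds than are shown below. What is called first, only, known or untested is meant among the compounds shown, and "the series" means these compounds.

For the measured compounds named here, in an ADME assay on microsomes from liver (Homo sapiens) for metabolic stability, read by LC-MS, tested at 1 uM (a higher number here means faster removal of the compound, a lower number slower removal), compound 3 (`NCCS(=O)(=O)CCOc1ccc([C@H]2CC[C@]3(CC2)OOC2(O3)C3CC4CC(C3)CC2C4)cc1`) gives 9 mL.min-1.g-1, the only true number so far. Compound 1 (`NCCCCCOc1ccc([C@H]2CC[C@]3(CC2)OOC2(O3)C3CC4CC(C3)CC2C4)cc1`) gives < 7 mL.min-1.g-1, which is a limit. Compound 2 (`NCCCOc1ccc([C@H]2CC[C@]3(CC2)OOC2(O3)C3CC4CC(C3)CC2C4)cc1`) gives < 7 mL.min-1.g-1, also a limit. Compound 4 (`c1cc([C@H]2CC[C@]3(CC2)OOC2(O3)C3CC4CC(C3)CC2C4)ccc1OCC1CCNCC1`) differs from compound 3 as follows: piperidin-4-yl in place of ((2-aminoethyl)sulfonyl)methyl on a saturated chain carbon bound to an oxygen on an aromatic ring. Two measured steps involve the (2-aminoethyl)sulfonyl group that compound 4 lacks: an at least 1.2-fold higher number from compound 1 to compound 3 (0.10 log units; that floor lies within the scatter), and an at least 1.2-fold higher number from compound 2 to compound 3 (0.10 log units; that floor lies within the scatter). Both are floors within the scatter. The remaining step is a step that the two limits leave unreadable from compound 1 to compound 2. Going by the values given here, no measured step therefore supports a change beyond the scatter in this assay, and none is expected. The expected change is a 1.1-fold lower number from compound 3 to compound 4 (0.05 log units; within the scatter). For compound 4 the estimate is 8 mL.min-1.g-1, with an expected range of 4 mL.min-1.g-1 to 16 mL.min-1.g-1.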

Compound 4, intrinsic clearance in microsomes: < 7 mL.min-1.g-1
Compound 4 gave a limit, no number; the forecaster's own chance of this, stated with the estimate: 40%; middle value at least 1.1-fold (0.05 log units) from the limit.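

In this assay, for the compounds shown here, the step of an at least 1.2-fold lower number from compound 3 to compound 4 (0.10 log units; that floor lies within the scatter) is the first reading for a ring at this position, piperidin-4-yl on a saturated chain carbon bound to an oxygen on an aromatic ring. The value of compound 4 is a limit, so this ring joins the open aminoalkyl chains of compound 1 and compound 2 at the same limit: the limit of < 7 mL.min-1.g-1 in this assay, at which 3 of the 4 values shown sit. The steps to compound 4 from compound 1 and from compound 2 cannot be read.

Any order among these three stays hidden under that limit. On these data alone, whether a carboxylic acid in place of the amine would move the number beyond the scatter remains open.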